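A few compounds are considered here, and "the series" means these few. Any claim that something is new, unique, unknown or untested is made for them only; others in the source may bear on it.

In a functional assay on HepG2 cells (Homo sapiens) for cytotoxicity, read by MTT assay, with a stated time of 72 h (on this read-out lower numbers stand for higher toxicity in this test and higher numbers for lower toxicity in this test), compound 1 `CS/C(=N\C(=O)c1ccno1)NC(=O)c1ccno1` gives only a limit, > 100000 nM. Compound 2 `O=C(/N=C(/NC(=O)c1ccno1)[Se]Cc1ccccc1)c1ccno1` also gives a limit in this assay, > 100000 nM. Within the data shown here, compound 3 `O=C(/N=C(/NC(=O)c1cccs1)[Se]Cc1ccccc1)c1cccs1` is the one compound with a number; in this assay compound 3 gives 81500 nM. The difference between the cores of compound 2 and compound 3 is not broken down here. Compound 1 arises from compound 2 by a group of 2 heavy atoms (1 carbon, 1 sulfur; no ring) in place of a group of 8 heavy atoms (7 carbon, 1 selenium; one six-membered aromatic ring of carbon only), on a carbon with a double bond to nitrogen, a step that the two limits leave unreadable from compound 2 to compound 1, unreadable because of the limit of > 100000 nM in this assay, at which 2 of the 3 values shown sit. Compound 4 `CS/C(=N\C(=O)c1cccs1)NC(=O)c1cccs1` is still to be measured; it arises from compound 3 by the same change, (a group of 2 heavy atoms (1 carbon, 1 sulfur; no ring) in place of a group of 8 heavy atoms (7 carbon, 1 selenium; one six-membered aromatic ring of carbon only), on a carbon with a double bond to nitrogen). Since the earlier step has no readable size, the expectation for compound 4 rests on compound 3 alone, which gives 81500 nM. Compound 4 is therefore expected to show a step of a 1.2-fold higher number from compound 3 to compound 4 (0.09 log units; within the scatter), close to nothing. The estimate for compound 4 is 100000 nM, from 40000 nM to 250000 nM, with a fair chance that only a limit is returned.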

Compound 4, concentration lethal to 50% of the cells: > 100000 nM
Compound 4 ended at the assay's limit; the forecaster's own chance of this, stated with the estimate: 55%; the middle value lies on the limit itself.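

In this assay, putting methylsulfanyl in place of the group with the six-membered aromatic ring, on a carbon with a double bond to nitrogen, gives an at least 1.2-fold higher number from compound 3 to compound 4 (0.08 log units; that floor lies within the scatter). Compound 4 gives > 100000 nM, which is a limit of the assay and not a number. The step therefore has only a floor, which lies within the scatter, and the same change on the core of compound 2 cannot be read, so the two cores show neither a shared size for this change nor a difference in it: the limit of > 100000 nM in this assay, at which 3 of the 4 values shown sit.

The compounds shown leave open what an amine or a longer chain on that same carbon would give in this assay. They also leave open how far above the limit compound 4 lies.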